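A few compounds are considered here, and "the series" means these few. Any claim that something is new, unique, unknown or untested is made for them only; others in the source may bear on it.

Measured compounds:
Compound 1 `Cc1cc(S(=O)(=O)N2C=CNC(=O)[C@H]2CC(=O)N2CCC(N(C)C)CC2)c(C)cc1Cl` gives 152 nM in an in vitro functional assay on cells for antagonist activity at B1 bradykinin receptor (Homo sapiens), read by luminescence and calcium flux, with a stated time of 2 h; a higher number here means a weaker inhibitor, a lower number a stronger inhibitor.
Compound 2 `Cc1cc(S(=O)(=O)N2C=CNC(=O)[C@H]2CC(=O)N2C[C@H]3CN(C)C[C@H]3C2)c(C)cc1Cl` gives 136 nM in this assay.

Among the measured compounds shown here, compound 2 and compound 1 sit within the scatter of each other, the only step between them being a 1.1-fold lower number from compound 1 to compound 2 (0.05 log units; within the scatter). Compound 3 `Cc1cc(S(=O)(=O)N2C=CNC(=O)[C@H]2CC(=O)N2CCC3(CCN(C)C3)C2)c(C)cc1Cl` differs from compound 2 only on the carbonyl carbon: a group of 10 heavy atoms (8 carbon, 2 nitrogen; 2 five-membered non-aromatic rings with 1 hetero atom each) in place of a group of 9 heavy atoms (7 carbon, 2 nitrogen; 2 five-membered non-aromatic rings with 1 hetero atom each), on a carbonyl carbon. For the measured compounds named here, the one measured step that bears on this position is a 1.1-fold lower number from compound 1 to compound 2 (0.05 log units; within the scatter), where exchanging one amine-bearing group for another of the same atom count left the number within the scatter. The change to compound 3 again exchanges one such group for a closely related one, so no step beyond the scatter is expected in this assay; the expected step is a 1.1-fold higher number from compound 2 to compound 3 (0.04 log units; within the scatter). Compound 3 is therefore estimated at 150 nM, with a range from 60 nM to 400 nM.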

Compound 3, half-maximal inhibitory concentration: 1.53 nM
Compound 3: middle estimate off by 98-fold (1.99 log units), on the high side; the measured number lies below the stated range.
By their numbers in this assay, from the lowest: compound 3; then compounds 2 and 1 (each within the scatter of the next).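

The carbonyl carbon proved far less tolerant than the earlier pair suggested in this assay: a closely related group now gives an 89-fold lower number from compound 2 to compound 3 (1.95 log units; beyond the scatter), and the comparison with the group holding one six-membered non-aromatic ring gives a 99-fold lower number from compound 1 to compound 3 (2.00 log units; beyond the scatter). This large change comes with only a small difference in the printed counts, as the entering group has one more carbon, the same counts of hydrogen-bond donors and acceptors, and no net charge. No supporting measurement is available to explain why this group stands so far apart from the other two.

The compounds shown do not separate which feature of the entering group carries the step, and that group has no defined stereocentres, so any difference between its individual stereoisomers remains unknown. On these data alone, whether a primary amine or a longer chain on the carbonyl carbon would keep the number this low also remains open.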